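Sulfonamide benzoxazoles: inhibition of the chaperone complex

The compounds below may be only part of what the source reports. "The series", "measured", "known", "first", "only" and "open" are said of these compounds alone.

Measured compounds:
compound 1 `Cc1ccccc1S(=O)(=O)Nc1ccc2oc(-c3ccccc3)nc2c1`: > 100000 nM
compound 2 `CS(=O)(=O)Nc1ccc(-c2nc3ccccc3o2)cc1`: > 100000 nM

In an assay on cells for inhibition of HSP60/HSP10 (Homo sapiens), with a stated time of 60 min (on this read-out lower numbers stand for stronger inhibition and higher numbers for weaker inhibition), compound 1 returns only a limit, > 100000 nM, not a number. Compound 2 likewise stops at the limit > 100000 nM in this assay. Both values sit at the limit of > 100000 nM in this assay, at which 2 of the 2 values shown sit, so compound 1 stands nowhere above or below anything shown; no measured step exists in this set.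

Compound 3 `CCc1ccc(S(=O)(=O)Nc2ccc3oc(-c4ccccc4)nc3c2)cc1` is not yet measured. It differs from compound 1 by 4-ethylphenyl in place of 2-methylphenyl on a sulfonyl sulfur. With both known values at the limit, the most that can be said is that compound 1 gives no measurable inhibition, and no evidence points to a change from the 4-ethylphenyl. The step from compound 1 to compound 3 is expected to lie within the scatter, that is none, as a number no higher from compound 1 to compound 3 (the limit leaves the size open). Compound 3 is therefore expected at 100000 nM, with a range from 30000 nM to 300000 nM, most likely again reported only as a limit.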

Compound 3, half-maximal inhibitory concentration: > 100000 nM
Compound 3 was reported as a limit; the forecaster's own chance of this, stated with the estimate: 80%; the middle value sits exactly at the limit.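

In this assay compound 3 gives only a limit, > 100000 nM. The step between compound 1 and compound 3 therefore cannot be read: the limit of > 100000 nM in this assay, at which 3 of the 3 values shown sit. The compounds shown leave open whether any group on the sulfonyl sulfur gives a number rather than a limit in this assay.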